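This account rests on a few compounds, and the source may have more. Where it says the series, first, only, none or still open, it means among the compounds named here.

Measured in an ADME assay on HepG2 cells (Homo sapiens) for cytotoxicity, with a stated time of 72 h; a lower number here means that less compound is needed, a higher number that more compound is needed for the effect:
- compound 1 `Cc1ccc(-c2nc3ccccc3s2)cc1NC(=O)c1cc([N+](=O)[O-])c(N2CCC(C(=O)O)CC2)cc1Cl`: > 25000 nM, a limit
- compound 2 `COc1ccc(-c2nc3ccccc3s2)cc1NC(=O)c1cc([N+](=O)[O-])c(N2CCC(C(=O)O)CC2)cc1Cl`: > 25000 nM, a limit

Compound 1 gives no number in this assay, only a limit, and compound 2 gives a limit as well. Together they offer (the limit of > 25000 nM in this assay, at which 2 of the 2 values shown sit).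

The next compound to be measured is compound 3 `Cc1ccc(-c2nc3ccccc3s2)cc1NC(=O)c1cc([N+](=O)[O-])ccc1Cl`. It differs from compound 1 by a single large change: hydrogen in place of 4-carboxypiperidin-1-yl on an aromatic carbon. In words, hydrogen stands in place of 4-carboxypiperidin-1-yl on an aromatic carbon.

For the measured compounds named here, the one measured step is a step that the two limits leave unreadable from compound 1 to compound 2. It swaps methoxy for methyl, has no readable size and says nothing about this change. Going by the values given here, both measured compounds carry the 4-carboxypiperidin-1-yl group, so the data hold no direct precedent for its loss.

With compound 1 reading > 25000 nM as a limit, only a modest move towards a lower number, meaning less compound needed, is expected, and another limit is quite possible. The expected change is an at least 1.2-fold lower number from compound 1 to compound 3 (0.09 log units; that floor lies within the scatter). For compound 3 the estimated value is 20000 nM, with an expected range from 6000 nM to 40000 nM.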

Compound 3, half-maximal effective concentration: > 14000 nM
Compound 3: a limit, no number; the forecaster's own chance of this, stated with the estimate: 60%; the middle value is on the limit's open side.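

Compound 1 and compound 3 both give only limits in this assay, and the step between them cannot be read. The compounds shown leave open whether hydrogen in place of 4-carboxypiperidin-1-yl changes the concentration needed for the effect at all, and what actual number any of the three compounds would reach in this assay.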